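The source may hold more compounds than are shown below. What is called first, only, known or untested is meant among the compounds shown, and "the series" means these compounds.

Going by the values given here, in an ADME assay on Caco-2 cells (Homo sapiens) for permeability, read by LC-MS, with a stated time of 2 h (a higher number here means that the compound crosses the layer faster, a lower number that the compound crosses the layer more slowly), compound 1 `CCCN(Cc1ccc(OCCN2C(=O)CCC2=O)c(C)c1)C(CC(=O)O)c1ccc(Cl)cc1` gives 10.2 nm/s and compound 2 `Cc1cc(CN(CC2CC2)C(CC(=O)O)c2ccc(Cl)cc2)ccc1OCCN1C(=O)CCC1=O` gives 5.2 nm/s, so compound 2 stands within the scatter of the only other measured number. Among the compounds with values here, the sole measured step, a 2.0-fold lower number from compound 1 to compound 2 (0.29 log units; within the scatter), stays within the scatter and concerns a different group. Compound 3 `Cc1cc(CN(CC2CC2)C(CC(=O)O)c2ccc(Cl)cc2)ccc1OCCn1c(=O)ccn(C)c1=O` differs from compound 2 by a group of 9 heavy atoms (5 carbon, 2 nitrogen, 2 oxygen; one six-membered aromatic ring with 2 hetero atoms) in place of a group of 7 heavy atoms (4 carbon, 1 nitrogen, 2 oxygen; one five-membered non-aromatic ring with 1 hetero atom), on a saturated chain carbon, two bonds along the chain from an oxygen on an aromatic ring. Within the data shown here, no measured step touches this group, so the data give no basis for a shift in either direction in this assay. The expected step is a 1.2-fold lower number from compound 2 to compound 3 (0.06 log units; within the scatter), which is none beyond the scatter. For compound 3 the estimate is 4.5 nm/s, with an expected range of 1.8 nm/s to 11 nm/s.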

Compound 3, apparent permeability: 3.7 nm/s
The estimate for compound 3 lay 1.2-fold (0.09 log units) above the measured number, within the range that was stated.
By their numbers in this assay, from the lowest: compounds 3, 2 and 1 (each within the scatter of the next, the first and the last beyond it).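

At the saturated chain carbon, two bonds along the chain from an oxygen on an aromatic ring, replacing 2,5-dioxopyrrolidin-1-yl with a six-membered aromatic ring with 2 hetero atoms gives in this assay a 1.4-fold lower number from compound 2 to compound 3 (0.15 log units; within the scatter) and so no step beyond the scatter. Ring size, aromaticity and hydrogen-bond acceptor count all differ in this one change, so their contributions cannot be separated. No supporting data bear on this step. Still open, going by these compounds, is whether an amine or a simple amide at this carbon would give a step beyond the scatter. On these data alone, a longer chain leading to either ring also remains open.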